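A few compounds are considered here, and "the series" means these few. Any claim that something is new, unique, unknown or untested is made for them only; others in the source may bear on it.

Compound 1 `COc1cc(OC)c(C(=O)/C=C/c2ccc(O)cc2)c(OC)c1` gives 49400 nM in a functional assay on A549 cells (Homo sapiens) for inhibition, read by MTT assay, with a stated time of 72 h; on this read-out lower numbers stand for stronger inhibition and higher numbers for weaker inhibition. Compound 2 `COc1cc(OC)c(C(=O)/C=C/c2ccc(O)c(O)c2)c(OC)c1` gives 8200 nM in this assay and so stands lowest of the two numbers measured. Compound 3 `COc1cc(OC)c(C(=O)/C=C/c2ccc(O)c(OC)c2)c(OC)c1` differs from compound 2 by methyl in place of hydrogen on an oxygen on an aromatic ring. Among the measured compounds shown here, no measured step covers this exact change; the only step in hand, a 6.0-fold lower number from compound 1 to compound 2 (0.78 log units; beyond the scatter), shows the gain on adding the hydroxy, and the methyl now sits on that oxygen, so a rise is expected that undoes part of that gain. The number for compound 3 is therefore estimated at 20000 nM (6000 nM to 60000 nM), an expected step of a 2.4-fold higher number from compound 2 to compound 3 (0.39 log units; beyond the scatter).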

Compound 3, half-maximal inhibitory concentration: 43800 nM
Compound 3: the middle estimate sits 2.2-fold (0.34 log units) below what was measured; the measured number falls inside the stated range.
By their numbers in this assay, from the lowest: compound 2; then compounds 3 and 1 (each within the scatter of the next).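

Methyl on this oxygen takes back what the hydroxy gained, a 5.3-fold higher number from compound 2 to compound 3 (0.73 log units; beyond the scatter), while methoxy in place of hydrogen on the aromatic carbon gives only a 1.1-fold lower number from compound 1 to compound 3 (0.05 log units; within the scatter). In this assay, the lower number of compound 2 therefore goes with the free hydroxy, not with just any oxygen-linked group at this place. No measurement in hand gives a reason for this. Still open, from the compounds shown here alone, is whether an amine at this place would hold the number of compound 2, and whether a longer chain on the oxygen would read like methyl.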